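The compounds below may be only part of what the source reports. "The series", "measured", "known", "first", "only" and "open" are said of these compounds alone.

Measured compounds:
- Compound 1, `COc1cccc(-n2cc(NC(=O)c3cccc(NS(=O)(=O)c4ccc(Cl)cc4)c3)cn2)c1`: 9430 nM
- Compound 2, `Cn1cc(NC(=O)c2ccc(NS(=O)(=O)c3ccccc3)cc2)cn1`: 58700 nM

Both compounds were tested in a functional assay on MCF7 cells (Homo sapiens) for inhibition, read by MTT assay, with a stated time of 48 h; a higher number here means a weaker inhibitor, a lower number a stronger inhibitor. Compound 2 stands at the higher of the two numbers: in this assay compound 2 gives 58700 nM, while compound 1 gives 9430 nM, a gap that lies beyond the scatter of the assay. For the measured compounds named here, compound 1 differs from compound 2 in more than one place, so no single step between the two is given; their two values show only that compound 1 is the stronger inhibitor of the pair.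

Compound 3, `Cc1ccc(-n2cc(NC(=O)c3ccc(NS(=O)(=O)c4ccccc4)cc3)cn2)cc1`, has not yet been measured. It differs from compound 2 in one place: 4-methylphenyl in place of methyl on an aromatic nitrogen. Compound 1, which carries a different aryl group on the same nitrogen, is more potent than compound 2, so an aryl group at this nitrogen is expected to lower the number, though the other differences between compound 1 and compound 2 leave this uncertain.

Compound 3 is therefore expected to be a moderately stronger inhibitor than compound 2, with an estimated step of a 3.9-fold lower number from compound 2 to compound 3 (0.59 log units; beyond the scatter). In this assay compound 3 is estimated at 15000 nM, within a range from 4000 nM to 50000 nM.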

Compound 3, half-maximal inhibitory concentration: 10900 nM
The estimate for compound 3 lay 1.4-fold (0.14 log units) above the measured number; the range from low to high includes it.
By their numbers in this assay, from the lowest: compounds 1 and 3 (each within the scatter of the next); then compound 2.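

In this assay, for the compounds shown here, the exchange of methyl for 4-methylphenyl on the aromatic nitrogen of the five-membered ring gives a 5.4-fold lower number from compound 2 to compound 3 (0.73 log units; beyond the scatter) and so isolates a change at this position for the first time, with the rest of the structure held fixed. The earlier gap between compound 1 and compound 2 combined the group on this nitrogen with other differences, whereas this pair links a lower number to the nitrogen substituent alone, in a change that adds one six-membered aromatic ring of carbon only and no hydrogen-bond donors or acceptors. Nothing measured here offers an explanation for the size of this step.

On these data alone, whether an unsubstituted phenyl, a benzyl group or a longer alkyl chain on this nitrogen would give a similar number remains open, so the step cannot yet be divided between the added ring and its methyl. Also open, as far as these compounds go, is whether an amine or a carboxylic acid on that ring would shift the number, and whether the same exchange would give a step of similar size on the core of compound 1.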